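Swapping Methyl for Fluoro on Compound 3

The source may report more compounds than this note shows. Statements on the series, on what has been measured and on what is new or still open speak of the compounds shown alone.

Compound 1 `COc1cc2c(cc1OC)C(=O)C(C(=O)Nc1ccccc1)C2` reads 61.3 ug/mL in a physicochemical assay, with a stated time of 30 min (a higher number here means a weaker inhibitor, a lower number a stronger inhibitor), and compound 2 `CCc1cccc(NC(=O)C2Cc3cc(OC)c(OC)cc3C2=O)c1` reads 64.1 ug/mL there, while compound 3 `COc1cc2c(cc1OC)C(=O)C(C(=O)Nc1ccccc1C)C2` reads 43.7 ug/mL on the same scale. These three values lie within the usual scatter of one another, so compound 3 stands level with the other two.

Compound 4 `COc1cc2c(cc1OC)C(=O)C(C(=O)Nc1ccccc1F)C2` is the next step. The change from compound 3 is fluoro in place of methyl on an aromatic carbon and in words it is fluoro in place of methyl on an aromatic carbon, ortho to a large group.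

Within the data shown here, three measured steps bear on it. Methyl in place of hydrogen gave a 1.4-fold lower number from compound 1 to compound 3 (0.15 log units; within the scatter) and ethyl in place of hydrogen gave a 1.0-fold higher number from compound 1 to compound 2 (0.02 log units; within the scatter) while 2-methylphenyl in place of 3-ethylphenyl gave a 1.5-fold lower number from compound 2 to compound 3 (0.17 log units; within the scatter) and all three stayed within the scatter. None of these compounds carries fluoro, so the evidence is indirect.

No step beyond the scatter is expected in this assay for this swap. The estimated shift is a 1.1-fold higher number from compound 3 to compound 4 (0.06 log units; within the scatter) and no more than that is expected. Compound 4 is expected at 50 ug/mL with an estimated range from 30 ug/mL to 80 ug/mL for repeated measurements.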

Compound 4, half-maximal inhibitory concentration: 75.7 ug/mL
For compound 4 the middle estimate is 1.5-fold (0.18 log units) below the measured one; the range from low to high includes it.
By their numbers in this assay, from the lowest: compounds 3, 1, 2 and 4 (each within the scatter of the next).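

Fluoro in place of methyl, on an aromatic carbon ortho to a large group, gives a 1.7-fold higher number from compound 3 to compound 4 (0.24 log units; within the scatter) in this assay and so this place takes a fluorine as well as a carbon group with no step beyond the scatter. Fluoro in place of hydrogen gives a 1.2-fold higher number from compound 1 to compound 4 (0.09 log units; within the scatter) and 2-fluorophenyl in place of 3-ethylphenyl gives a 1.2-fold higher number from compound 2 to compound 4 (0.07 log units; within the scatter) so all four compounds now stand level on this scale. Nothing measured here explains why these groups read alike.

The compounds shown carry only hydrogen, methyl, ethyl and fluoro on this phenyl ring, so it stays open whether an amine, a carboxylic acid or a longer chain would move the number beyond the scatter. Going by these compounds, it also stays open whether fluoro elsewhere on the ring would read the same.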